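This account rests on a few compounds, and the source may have more. Where it says the series, first, only, none or still open, it means among the compounds named here.

Measured so far in an assay on HeLa cells for inhibition of 17-beta-hydroxysteroid dehydrogenase type 3 (Homo sapiens); on this read-out higher numbers stand for weaker inhibition and lower numbers for stronger inhibition:
compound 1 `O=c1cc(CSc2ccncc2)c2ccc(O)cc2o1` gives 5000 nM
compound 2 `O=c1cc(CSc2cccs2)c2ccc(O)cc2o1` gives 420 nM
compound 3 `O=c1cc(CSc2nccs2)c2ccc(O)cc2o1` gives 10 nM

Compound 3 stands lowest of the three numbers; the steps leading to it are a 500-fold lower number from compound 1 to compound 3 (2.70 log units; beyond the scatter) and a 42-fold lower number from compound 2 to compound 3 (1.62 log units; beyond the scatter), both beyond the scatter.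

Compound 4 `Cn1ccnc1SCc1cc(=O)oc2cc(O)ccc12` differs from compound 3 in one place: 1-methyl-1H-imidazol-2-yl in place of 1,3-thiazol-2-yl on a sulfur. All three measured steps bear on it, since each exchanges the aromatic ring on this sulfur: a 12-fold lower number from compound 1 to compound 2 (1.08 log units; beyond the scatter), a 500-fold lower number from compound 1 to compound 3 (2.70 log units; beyond the scatter), a 42-fold lower number from compound 2 to compound 3 (1.62 log units; beyond the scatter). Every such exchange moved this assay by more than the scatter, so a step beyond the scatter is expected here too, more likely toward a higher number because compound 3 already sits at 10 nM, the lowest seen. For compound 4 the number is expected at 60 nM, between 10 nM and 400 nM. That estimate amounts to an expected step of a 6.0-fold higher number from compound 3 to compound 4 (0.78 log units; beyond the scatter).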

Compound 4, half-maximal inhibitory concentration: 91 nM
The estimate for compound 4 lay 1.5-fold (0.18 log units) below the measured number; the range from low to high includes it.
By their numbers in this assay, from the lowest: compound 3; then compound 4; then compound 2; then compound 1.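

In this assay a ring without sulfur on this position still gives a low number, though not the lowest: a 9.1-fold higher number from compound 3 to compound 4 (0.96 log units; beyond the scatter) stands against a 4.6-fold lower number from compound 2 to compound 4 (0.66 log units; beyond the scatter) and a 55-fold lower number from compound 1 to compound 4 (1.74 log units; beyond the scatter) in the same series. Compound 3 and compound 4 both carry one five-membered aromatic ring with 2 hetero atoms and 2 hydrogen-bond acceptors, so these counts alone do not set the number here. No measurement at hand explains this order of rings.

Open, going by these compounds, is whether the methyl or the ring exchange carries the step, which 1H-imidazol-2-yl on this sulfur would separate, and how an amine or carboxylic acid on the 1,3-thiazol-2-yl ring would read.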